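Dithiocarbamate amine variation in a benzamide series

The source may report more compounds than this note shows. Statements on the series, on what has been measured and on what is new or still open speak of the compounds shown alone.

Three compounds share one core. Compound 1 `Nc1ccccc1NC(=O)c1ccc(CSC(=S)N2CCN(c3ccc(Cl)cc3)CC2)cc1` gives 32.2% in a functional assay on A-375 cells (Homo sapiens) for antiproliferative activity, read by CCK-8 assay, with a stated time of 72 h, tested at 2 uM; a higher number here means a stronger effect of the compound at the concentration tested, a lower number a weaker effect. Compound 2 `Nc1ccccc1NC(=O)c1ccc(CSC(=S)N2CCc3cc([N+](=O)[O-])ccc32)cc1` gives 16.9% in this assay. Compound 3 `CC1CCN(C(=S)SCc2ccc(C(=O)Nc3ccccc3N)cc2)CC1` gives 32.7% in this assay, the highest of the three numbers, though compound 1 sits within the scatter of it and only compound 2 lies beyond it. Compound 4 `Nc1ccccc1NC(=O)c1ccc(CSC(=S)N2CCCc3ccccc32)cc1` is not yet measured. It differs from compound 3 by 1,2,3,4-tetrahydroquinolin-1-yl in place of 4-methylpiperidin-1-yl on a thiocarbonyl carbon. For the measured compounds named here, no step between measured compounds is known, so the size of this step is open; a modest downward step is expected, near the edge of the scatter, because compound 2, also carrying a ring-fused amine, gives 16.9%. Compound 4 is estimated at 25% in this assay, between 12% and 38%. The expected step is a number 7.7 percentage points lower from compound 3 to compound 4 (within the scatter).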

Compound 4, a percentage reported as inhibition, at one concentration (the size of the read-out at that concentration, not a potency): 26.5%
Estimate against measurement, compound 4: 1.5 percentage points below; the range from low to high includes it.
By their numbers in this assay, from the lowest: compounds 2, 4, 1 and 3 (each within the scatter of the next, the first and the last beyond it).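

For the compounds shown here, this is the first step that can be read: on a thiocarbonyl carbon, 1,2,3,4-tetrahydroquinolin-1-yl in place of 4-methylpiperidin-1-yl gives a number 6.2 percentage points lower from compound 3 to compound 4 (within the scatter) in this assay. An added six-membered aromatic ring of carbon only is therefore accommodated at this position without a step beyond the scatter. No measurement shown gives a reason for the size of this step.

On these data alone, open-chain diethylamino or morpholin-4-yl on the same thiocarbonyl carbon remains open. So does the outcome of a methoxy group on the aromatic ring of compound 4.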